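This account rests on a few compounds, and the source may have more. Where it says the series, first, only, none or still open, it means among the compounds named here.

In an ADME assay on the whole organism for metabolic stability, with Rattus norvegicus as the target (a higher number here means that the compound lasts longer, a lower number that the compound disappears faster), compound 1 `CSCC[C@H](NC(=O)c1ccc(CN(Cc2ccccc2)c2cnccn2)cc1-c1ccccc1C)C(=O)O` gives < 0.4 h. That figure is a limit of the assay and not a number. Compound 1 therefore stands at the limit of < 0.4 h in this assay, at which 1 of the 2 values shown sits. The other measured compound, compound 2 `CSCC[C@H](NC(=O)c1ccc(CN(Cc2cc(F)cc(F)c2)c2cccnc2)cc1-c1ccccc1C)C(=O)O`, gives 1 h, which is a true number.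

Compound 3 `CSCC[C@H](NC(=O)c1ccc(CN(Cc2ccccc2)c2cncc(F)c2)cc1-c1ccccc1C)C(=O)O` keeps the core of compound 1 and changes one group, with 5-fluoropyridin-3-yl in place of pyrazin-2-yl on an amine nitrogen. Among the measured compounds shown here, no measured pair of compounds shows this change alone, so any forecast is uncertain. The closest guide is compound 2, which also carries a different group on that amine nitrogen, but it differs elsewhere too. Since compound 2 gives 1 h, a small rise in this assay is a reasonable expectation, though one that may not clear the usual scatter of repeated measurements. The expected change is an at least 1.5-fold higher number from compound 1 to compound 3 (0.17 log units; that floor lies within the scatter), and its true size is hard to judge with only a limit as the starting point. For compound 3 the estimated half-life is 0.6 h, with an expected range of 0.3 h to 1.3 h.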

Compound 3, half-life: < 0.4 h
Compound 3 ended at the assay's limit; the forecaster's own chance of this, stated with the estimate: 35%; middle value at least 1.5-fold (0.17 log units) away from the limit.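

Compound 1 and compound 3 both end at a limit of this assay and not at a number, so no step between them can be read: the limit of < 0.4 h in this assay, at which 2 of the 3 values shown sit.

The compounds shown leave open whether 5-fluoropyridin-3-yl in place of pyrazin-2-yl on an amine nitrogen changes the half-life at all, and in which direction.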